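Series notes: one aryl substituent change from compound 1

The source may hold more compounds than are shown below. What is called first, only, known or untested is meant among the compounds shown, and "the series" means these compounds.

Measured in a functional assay on HCT-116 cells (Homo sapiens) for inhibition, read by sulforhodamine B assay, with a stated time of 72 h; on this read-out higher numbers stand for weaker inhibition and lower numbers for stronger inhibition:
compound 1 `CC(c1ccc(-c2ccccc2)c(F)c1)c1nnc2n1N=C(c1ccc(OC(F)(F)F)cc1)CS2` gives 5400 nM
compound 2 `COc1ccc2cc(C(C)c3nnc4n3N=C(c3ccc(Cl)cc3Cl)CS4)ccc2c1` gives 14000 nM
compound 3 `COc1ccc2cc(C(C)c3nnc4n3N=C(c3ccc(C(F)(F)F)cc3)CS4)ccc2c1` gives 10800 nM

Among the three numbers compound 1 gives the lowest, though its gap to compound 3 lies within the scatter; only the gap to compound 2 is beyond it. Compound 4 `Cc1ccc(C2=Nn3c(nnc3C(C)c3ccc(-c4ccccc4)c(F)c3)SC2)cc1` differs from compound 1 by methyl in place of trifluoromethoxy on an aromatic carbon. Among the measured compounds shown here, the one measured step touching the same aryl is a 1.3-fold lower number from compound 2 to compound 3 (0.11 log units; within the scatter), a change of that aryl that stayed within the scatter. For the measured compounds named here, no measured pair sets trifluoromethoxy against methyl directly. On this basis the expected step of a 1.1-fold higher number from compound 1 to compound 4 (0.05 log units; within the scatter) is none beyond the scatter. For compound 4 the estimate in this assay is 6000 nM, with a range from 2500 nM to 15000 nM.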

Compound 4, half-maximal inhibitory concentration: 4800 nM
For compound 4 the middle estimate is 1.3-fold (0.10 log units) above the measured one; the measured number falls inside the stated range.
By their numbers in this assay, from the lowest: compounds 4, 1, 3 and 2 (each within the scatter of the next, the first and the last beyond it).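

In this assay, among the compounds shown here, trifluoromethoxy and methyl are set directly against each other for the first time at this place, para to a large group, and the swap gives a 1.1-fold lower number from compound 1 to compound 4 (0.05 log units; within the scatter) with the rest of compound 1 unchanged. On this pair the read-out does not separate the two groups, although the one leaving carries oxygen and fluorine and the one entering carbon only. Nothing measured on either group offers an explanation for this result. Open, on these data alone, is whether an amine, a carboxylic acid or a longer chain at this place would also stay within the scatter of compound 1. Also open, as far as these compounds go, is whether methyl would read the same on the scaffold of compound 3.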